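Replacing the Azido Group of Compound 3 with a (3-(Dimethylamino)propoxy)methyl Chain

A few compounds are considered here, and "the series" means these few. Any claim that something is new, unique, unknown or untested is made for them only; others in the source may bear on it.

Compound 1 `C[S+]([O-])c1c(F)c(N)c2c(=O)cc(-c3ccc(N)c(F)c3)oc2c1F`: > 100000 nM
Compound 2 `Nc1ccc(-c2cc(=O)c3c(N)c(F)c(O)c(F)c3o2)cc1F`: > 100000 nM
Compound 3 `[N-]=[N+]=Nc1c(F)c(N)c2c(=O)cc(-c3ccc(N)c(F)c3)oc2c1F`: 1200 nM

Of the compounds shown here, three of a shared core have been tested in a functional assay on HeLa cells (Homo sapiens) for cytotoxicity, read by neutral red uptake, with a stated time of 3 days; on this read-out higher numbers stand for weaker inhibition and lower numbers for stronger inhibition. Compound 1 gives > 100000 nM, which is a limit of the assay and not a number. Compound 2 likewise gives > 100000 nM, again a limit. Within the data shown here, compound 3 gives 1200 nM, the only number among the three. The other two values are limits of the assay (the limit of > 100000 nM in this assay, at which 2 of the 3 values shown sit). The steps to it are an at least 83-fold lower number from compound 1 to compound 3 (1.92 log units; beyond the scatter) and an at least 83-fold lower number from compound 2 to compound 3 (1.92 log units; beyond the scatter), while a step that the two limits leave unreadable from compound 1 to compound 2.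

Compound 4 `CN(C)CCCOCc1c(F)c(N)c2c(=O)cc(-c3ccc(N)c(F)c3)oc2c1F` has not been measured. It differs from compound 3 in one place: (3-(dimethylamino)propoxy)methyl in place of azido on an aromatic carbon. Among the measured compounds shown here, no measured step puts this chain in, but both measured steps show that the azido group is the one feature that separates a number from a limit: whenever it is replaced by hydroxy or by the methylsulfinyl group, the value rises to the limit. He therefore expects the replacement by (3-(dimethylamino)propoxy)methyl to raise the number markedly, with a fair chance of reaching the limit again. For compound 4 he estimates 30000 nM, within 4000 nM to 150000 nM, an expected step of a 25-fold higher number from compound 3 to compound 4 (1.40 log units; beyond the scatter).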

Compound 4, half-maximal inhibitory concentration: 12000 nM
Estimate against measurement, compound 4: 2.5-fold (0.40 log units) above, within the range that was stated.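

In this assay, among these compounds, azido proves not to be the only group at this position, ortho to two fluoro groups, that gives a number rather than a limit, although the change to the (3-(dimethylamino)propoxy)methyl chain still costs activity, with a 10-fold higher number from compound 3 to compound 4 (1.00 log units; beyond the scatter). Measured against the hydroxy and methylsulfinyl groups at the same carbon, the chain stands clearly lower, with an at least 8.3-fold lower number from compound 2 to compound 4 (0.92 log units; beyond the scatter) and an at least 8.3-fold lower number from compound 1 to compound 4 (0.92 log units; beyond the scatter). Both of these steps start from a limit and not from a number, so their full size stays unknown: the limit of > 100000 nM in this assay, at which 2 of the 4 values shown sit.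

The compounds shown cannot separate the contributions of the chain's ether oxygen, its dimethylamino end and its length, and a propoxymethyl chain without the amine or a chain ending in a carboxylic acid would bear on that question. They also leave open whether a small group at this carbon, such as a nitrile or a primary amine, would come as close to compound 3 as the long chain of compound 4 does, or closer.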